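Replacing the amide piperazine with a hydroxypiperidine

The compounds below may be only part of what the source reports. "The series", "measured", "known", "first", "only" and "open" are said of these compounds alone.

Measured so far:
compound 1, `Cc1nc(N2CCN(S(C)(=O)=O)CC2)nc2ccc(NC(=O)COc3ccc(Cl)cc3)cc12`: > 10000 nM
compound 2, `Cc1nc(N2CCN(C(=O)C3CC3)CC2)nc2ccc(NC(=O)COc3ccc(OC(F)(F)F)cc3)cc12`: 30 nM

In a functional assay on CHO-K1 cells for antagonist activity at melanin-concentrating hormone receptor 1 (Homo sapiens), read by inositol phosphate accumulation (a higher number here means a weaker inhibitor, a lower number a stronger inhibitor), compound 1 gives only a limit, > 10000 nM. Compound 2 gives 30 nM in this assay, the only number shown here. Compound 3, `Cc1nc(N2CCC(O)(C3CC3)CC2)nc2ccc(NC(=O)COc3ccc(OC(F)(F)F)cc3)cc12`, differs from compound 2 in one place: 4-cyclopropyl-4-hydroxypiperidin-1-yl in place of 4-(cyclopropylcarbonyl)piperazin-1-yl on an aromatic carbon. Among the measured compounds shown here, no measured pair shows this change, so the expected step is within the usual scatter: a 1.7-fold higher number from compound 2 to compound 3 (0.22 log units; within the scatter). Compound 3 is estimated at 50 nM in this assay, with a likely range from 10 nM to 300 nM.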

Compound 3, half-maximal inhibitory concentration: 33 nM
Compound 3: middle estimate off by 1.5-fold (0.18 log units), on the high side, within the range that was stated.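

In this assay the swap gives a 1.1-fold higher number from compound 2 to compound 3 (0.04 log units; within the scatter), so at this position a 4-cyclopropyl-4-hydroxypiperidin-1-yl group can stand in for the 4-(cyclopropylcarbonyl)piperazin-1-yl group. The pair shows that this position accepts losing the carbonyl and the second ring nitrogen while gaining a hydrogen-bond donor, with the two values within the scatter of each other. Nothing in the data shown explains this result. From the compounds shown here alone, whether the hydroxyl matters remains open: a methoxy group or an amine could stand in its place. A longer chain in place of the cyclopropyl is equally untested here.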